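The source may hold more compounds than are shown below. What is called first, only, known or untested is meant among the compounds shown, and "the series" means these compounds.

Measured compounds in the series:

Compound 1 `O=C(O)c1cc(OCc2ccccc2)ccc1O`; in an ADME assay on NCI-H630 cells (Homo sapiens) for cytotoxicity, read by MTT assay, with a stated time of 72 h (on this read-out lower numbers stand for higher toxicity in this test and higher numbers for lower toxicity in this test), compound 1 gives > 40000 nM, which is a limit of the assay and not a number.
Compound 2 `O=C(NCc1cccs1)c1cccc(O)c1O`; in this assay compound 2 gives > 40000 nM, again a limit.
Compound 3 `O=C(NCc1ccco1)c1cccc(O)c1O`; in this assay compound 3 gives > 40000 nM, also a limit.

Compound 3 therefore stands only at a limit, and the two other values shown are limits as well, all three sitting at the limit of > 40000 nM in this assay, at which 3 of the 3 values shown sit. For the measured compounds named here, the one step between measured neighbours, a step that the two limits leave unreadable from compound 2 to compound 3, is left unreadable by the two limits, so it gives no size in either direction.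

Compound 4 `O=C(NCC1CCCCC1)c1cccc(O)c1O` is the next member, to be run in this assay. It differs from compound 3 by cyclohexyl in place of furan-2-yl on a saturated chain carbon bound to an amide-type nitrogen. Going by the values given here, no measured step bears readably on this change; the only neighbouring step is itself unreadable. With every value in the series at the limit, compound 4 is expected to sit at the limit too, with a step from compound 3 estimated as a number no higher from compound 3 to compound 4 (the limit leaves the size open), meaning none beyond the scatter. The estimate for compound 4 is 40000 nM, with a range from 20000 nM to 100000 nM.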

Compound 4, half-maximal cytotoxic concentration: 21000 nM
Compound 4: middle estimate off by 1.9-fold (0.28 log units), on the high side, within the range that was stated.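

For the compounds shown here, compound 4 is the first member of the series to give a number rather than a limit in this assay, so the place on a saturated chain carbon bound to an amide-type nitrogen can now be tied to a readable value. Cyclohexyl in place of furan-2-yl gives an at least 1.9-fold lower number from compound 3 to compound 4 (0.27 log units; that floor lies within the scatter), and cyclohexyl in place of thiophen-2-yl gives an at least 1.9-fold lower number from compound 2 to compound 4 (0.27 log units; that floor lies within the scatter); both are floors, so neither step is shown to go beyond the scatter, and their true sizes stay unknown. All the other values in the series remain limits: the limit of > 40000 nM in this assay, at which 3 of the 4 values shown sit.

From the compounds shown here alone, whether phenyl, cyclopentyl or an amine at this same place would give a number or stay at the limit remains open. The compounds shown also leave open whether the step follows from the saturated ring itself or from the loss of the five-membered aromatic ring.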